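Swapping the amino alcohol group on a shared core

This account rests on a few compounds, and the source may have more. Where it says the series, first, only, none or still open, it means among the compounds named here.

Measured in a functional assay on G-361 cells (Homo sapiens) for cytotoxicity, read by fluorescence, with a stated time of 72 h; a higher number here means a weaker inhibitor, a lower number a stronger inhibitor:
- compound 1 `CC(C)c1n[nH]c2c(NCc3ccc(-c4ccccn4)cc3)nc(S(C)(=O)=O)nc12` gives 793 nM
- compound 2 `CC(C)c1n[nH]c2c(NCc3ccc(-c4ccccn4)cc3)nc(NCC(C)(C)O)nc12` gives 48 nM

Of these two numbers, compound 2 holds the lower, 48 nM, so it is the stronger inhibitor of the pair. The unmeasured compound 3 `CC(C)c1n[nH]c2c(NCc3ccc(-c4ccccn4)cc3)nc(N3CCCCC3CCO)nc12` keeps the shared core and changes one group: 2-(2-hydroxyethyl)piperidin-1-yl in place of (2-hydroxy-2-methylpropyl)amino on an aromatic carbon. The entering group brings a six-membered non-aromatic ring.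

Going by the values given here, only one measured step bears on this change: a 17-fold lower number from compound 1 to compound 2 (1.22 log units; beyond the scatter). That large step, at the same carbon, shows that the number in this assay can move strongly with the group placed there. It started from methylsulfonyl, however, so it says little about exchanging one hydroxy-bearing group for another. Among the compounds with values here, no measured compound carries a ring at this place, which leaves the direction open, and only a modest step is expected. The estimated change is a 1.4-fold lower number from compound 2 to compound 3 (0.14 log units; within the scatter). For compound 3 the estimate is 35 nM, with an expected range of 10 nM to 130 nM.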

Compound 3, half-maximal inhibitory concentration: 204 nM
Estimate against measurement, compound 3: 5.8-fold (0.77 log units) below, outside the stated range (above it).
By their numbers in this assay, from the lowest: compound 2; then compound 3; then compound 1.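

In this assay, exchanging the open-chain (2-hydroxy-2-methylpropyl)amino for the ring-bearing 2-(2-hydroxyethyl)piperidin-1-yl gives a 4.3-fold higher number from compound 2 to compound 3 (0.63 log units; beyond the scatter), so a higher number here means a weaker inhibitor and these two hydroxy-bearing groups are not interchangeable at this carbon. The ring-bearing group still improves on methylsulfonyl, with a 3.9-fold lower number from compound 1 to compound 3 (0.59 log units; beyond the scatter), so both groups that replace methylsulfonyl in these compounds give a lower number, but by clearly different amounts. No measurement shown here explains the difference between the two hydroxy-bearing groups.

The change from compound 2 to compound 3 alters several things at once: the ring, the chain carrying the hydroxyl, and the branching of that chain, so the step cannot be assigned to any one of them. A plain piperidin-1-yl group without the hydroxyethyl chain and a simple unbranched (2-hydroxyethyl)amino group at the same carbon would help pull these features apart, and the shown compounds leave open how either would behave.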